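The source may hold more compounds than are shown below. What is called first, only, known or untested is meant among the compounds shown, and "the series" means these compounds.

Three compounds that share one core were measured in a functional assay on H184B5F5/M10 cells (Homo sapiens) for antiproliferative activity, read by XTT assay, with a stated time of 72 h; on this read-out higher numbers stand for weaker inhibition and lower numbers for stronger inhibition. Compound 1 `COc1ccc(-c2cc3ccccc3nc2/C=C/C(=O)c2ccc(N)cc2)cc1` gives 9290 nM. Compound 2 `COc1ccc(-c2cc3ccccc3nc2/C=C/C(=O)c2ccco2)cc1` gives 6240 nM, and compound 3 `COc1ccc(-c2cc3ccccc3nc2/C=C/C(=O)c2ccc(Br)s2)cc1` gives 9380 nM, the highest of the three numbers, although every gap among them lies within the scatter: a 1.5-fold lower number from compound 1 to compound 2 (0.17 log units; within the scatter), a 1.0-fold higher number from compound 1 to compound 3 (0.00 log units; within the scatter) and a 1.5-fold higher number from compound 2 to compound 3 (0.18 log units; within the scatter). Compound 4 `COc1ccc(-c2cc3ccccc3nc2/C=C/C(=O)c2ccc[nH]2)cc1` differs from compound 3 in one place: 1H-pyrrol-2-yl in place of 5-bromothiophen-2-yl on a carbonyl carbon. All three measured steps swap the group on the same carbonyl carbon, and none of them moved the number beyond the scatter, so for compound 4 no step beyond the scatter in this assay is expected, a 1.2-fold lower number from compound 3 to compound 4 (0.07 log units; within the scatter). Compound 4 is therefore estimated at 8000 nM, within a range from 3500 nM to 18000 nM.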

Compound 4, half-maximal inhibitory concentration: > 10000 nM
Compound 4 was reported as a limit (the forecaster's own chance of this, stated with the estimate: 5%); middle value at least 1.2-fold (0.09 log units) away from the limit.
By their numbers in this assay, from the lowest: compounds 2, 1 and 3 (each within the scatter of the next). At a limit, above all of these: compound 4.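

In this assay, among the compounds shown here, the 1H-pyrrol-2-yl group on this carbonyl carbon is the first change here to give a limit and not a number: the limit of > 10000 nM in this assay, at which 1 of the 4 values shown sits. The steps read an at least 1.0-fold higher number from compound 3 to compound 4 (0.02 log units; that floor lies within the scatter) and an at least 1.6-fold higher number from compound 2 to compound 4 (0.20 log units; that floor lies within the scatter) and also an at least 1.0-fold higher number from compound 1 to compound 4 (0.03 log units; that floor lies within the scatter) and so each floor stays within the scatter, and none of them sets compound 4 apart from the other compounds.

As far as these compounds go, how far compound 4 lies past its limit stays open. So does whether a plain phenyl or a pyridin-2-yl on the same carbonyl carbon would give a number clearly apart from these.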